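The source may hold more compounds than are shown below. What is called first, only, known or untested is meant among the compounds shown, and "the series" means these compounds.

Compound 1 `c1cncc(N2CC[C@H]3CN[C@H]3C2)c1` gives 71 nM in a functional assay on HEK293 cells for agonist activity at Neuronal acetylcholine receptor; alpha4/beta2 (Homo sapiens), read by FLIPR; a lower number here means that less compound is needed, a higher number that more compound is needed for the effect. For the measured compounds named here, compound 2 `Brc1cncc(N2CC[C@H]3CN[C@H]3C2)c1` gives 150 nM in this assay, the highest of the two numbers so far; the step of a 2.1-fold higher number from compound 1 to compound 2 (0.32 log units; beyond the scatter) is modest. Compound 3 `N#Cc1cncc(N2CC[C@H]3CN[C@H]3C2)c1` carries cyano in place of bromo on an aromatic carbon. Going by the values given here, the only measured step touching this aromatic carbon is a 2.1-fold higher number from compound 1 to compound 2 (0.32 log units; beyond the scatter), a substituent entering in place of hydrogen; no step from bromo to cyano has been measured, and the direction is therefore open. For compound 3 the expected step is a 1.5-fold lower number from compound 2 to compound 3 (0.18 log units; within the scatter), within the size already seen. Compound 3 is estimated at 100 nM, range 35 nM to 300 nM.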

Compound 3, half-maximal effective concentration: 1900 nM
The estimate for compound 3 lay 19-fold (1.28 log units) below the measured number, and the stated range ends below it.
By their numbers in this assay, from the lowest: compound 1; then compound 2; then compound 3.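

At this aromatic carbon, two atoms from the ring nitrogen, the identity of the substituent matters far more than the bromo step alone could show: in this assay cyano gives a 13-fold higher number from compound 2 to compound 3 (1.10 log units; beyond the scatter) and also a 27-fold higher number from compound 1 to compound 3 (1.43 log units; beyond the scatter), both large. Replacing hydrogen at this carbon is thus not a uniformly modest change, and the size of the step depends on the group that enters. Nothing available bears on the origin of this difference.

As far as these compounds go, whether an amine, a methoxy group or a carboxylic acid at this carbon would lie nearer compound 1 or compound 3 remains open. The compounds shown also leave open whether the cyano step would carry over to other ring carbons.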